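This account rests on a few compounds, and the source may have more. Where it says the series, first, only, none or still open, it means among the compounds named here.

Measured compounds:
- compound 1 `c1cncc(CN(CCCCN(C[C@H]2Cc3ccccc3CN2)[C@H]2CCCc3cccnc32)Cc2cccnc2)c1` in a functional assay on cells for antagonist activity at C-X-C chemokine receptor type 4 (Homo sapiens), read by fluorescence and calcium flux, with stated times of 25 min and 90 s; a lower number here means a stronger inhibitor, a higher number a weaker inhibitor: 471 nM
- compound 2 `c1ccc2c(c1)CN[C@@H](CN(CCCCNCC1CCOCC1)[C@H]1CCCc3cccnc31)C2` in this assay: 52.9 nM

For the measured compounds named here, compound 2 holds the lowest number of the two measured in this assay; the only neighbour is compound 1, which sits at a higher number by a gap that lies beyond the scatter. Going by the values given here, the two compounds differ in more than one place, so what their values show is only that compound 2 is the stronger inhibitor of the pair.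

Compound 3 `CC1(C)CCC(NCCCCN(C[C@H]2Cc3ccccc3CN2)[C@H]2CCCc3cccnc32)CC1` is not yet measured. It differs from compound 2 in a single place: 4,4-dimethylcyclohexyl in place of (oxan-4-yl)methyl on an amine nitrogen. The amine that carries the group keeps its other neighbour, a saturated chain carbon, and the rest of the shared core is unchanged.

Among the compounds with values here, no measured step of this kind is available, so the step in this assay from compound 2 to compound 3 is expected to be small, likely within the scatter, with no firm direction; the step of a 1.1-fold higher number from compound 2 to compound 3 (0.05 log units; within the scatter) states this expectation. For compound 3 in this assay the estimate is 60 nM, expected to fall between 20 nM and 200 nM.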

Compound 3, half-maximal inhibitory concentration: 77.6 nM
Compound 3: the middle estimate sits 1.3-fold (0.11 log units) below what was measured; the measured number falls inside the stated range.
By their numbers in this assay, from the lowest: compounds 2 and 3 (each within the scatter of the next); then compound 1.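

In this assay, for the compounds shown here, the change to 4,4-dimethylcyclohexyl in place of (oxan-4-yl)methyl on this amine nitrogen gives a 1.5-fold higher number from compound 2 to compound 3 (0.17 log units; within the scatter) and is the only single-place step so far. The amine nitrogen thus carries either group with no difference beyond the scatter, so the oxygen of the outgoing ring, its one hydrogen-bond acceptor, is not required for a value in this range. No supporting measurement is available to explain why the two groups read alike.

One step on this nitrogen cannot show whether the position also accepts groups of another kind, such as a piperidin-4-yl ring with its own amine, a cyclohexyl ring bearing a carboxylic acid, or a plain longer alkyl chain. As far as these compounds go, compound 1 differs from the other two compounds in more than one place, so it gives no clean reading of what a second substituent on this nitrogen would do, and that question stays open.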